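This account rests on a few compounds, and the source may have more. Where it says the series, first, only, none or still open, it means among the compounds named here.

Measured compounds, with their results in an assay on isolated protein for inhibition of endothelial lipase (Homo sapiens), read by LC-MS, with a stated time of 2 h, in the presence of a further agent that is not named here; on this read-out lower numbers stand for stronger inhibition and higher numbers for weaker inhibition:

Compound 1, `Nc1c(C(=O)N[C@H]2CC[C@@H](c3ccccc3)CC2)[nH]c(=O)[nH]c1=O`: in this assay compound 1 gives "not determined" (no result reported).
Compound 2, `O=C(N[C@H]1CC[C@@H](c2ccccc2)CC1)c1[nH]c(=O)[nH]c(=O)c1NC1CCCC1`: in this assay compound 2 gives 436000 nM.
Compound 3, `O=C(N[C@H]1CC[C@@H](c2ccccc2)CC1)c1[nH]c(=O)[nH]c(=O)c1O`: in this assay compound 3 gives 25000 nM.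

Within the data shown here, compound 3 thus holds the lowest number of the two that were obtained, and the only measured step, a 17-fold lower number from compound 2 to compound 3 (1.24 log units; beyond the scatter), is large and points towards compound 3. Compound 4, `O=C(N[C@H]1CC[C@@H](c2ccccc2)CC1)c1[nH]c(=O)n(CCO)c(=O)c1O`, differs from compound 3 by 2-hydroxyethyl in place of hydrogen on an aromatic nitrogen. Among the measured compounds shown here, no measured step touches that ring nitrogen; the one known step concerns a different place on the shared core, so it gives no direct guide here. The expectation for compound 4 is therefore a number close to that of compound 3, with a step of a 1.3-fold lower number from compound 3 to compound 4 (0.10 log units; within the scatter) that may well stay within the scatter. The estimate for compound 4 in this assay is 20000 nM, expected to lie between 5000 nM and 80000 nM.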

Compound 4, half-maximal inhibitory concentration: > 143000 nM
Compound 4: only a limit was reported; the forecaster's own chance of this, stated with the estimate: 10%; middle value at least 7.1-fold (0.85 log units) away from the limit.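

Among these compounds, this aromatic nitrogen, which no earlier step touched, does not tolerate every change: 2-hydroxyethyl in place of hydrogen gives an at least 5.7-fold higher number from compound 3 to compound 4 (0.75 log units; beyond the scatter) in this assay, so inhibition weakens beyond the scatter. Compound 4 yields only a limit, not a number: the limit of > 143000 nM in this assay, at which 1 of the 4 values shown sits.

The compounds shown leave open whether this loss belongs to 2-hydroxyethyl in particular or to any group on that nitrogen. A methyl group, a longer chain, an amine or a carboxylic acid at the same place would be needed to separate these two readings.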